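The compounds below may be only part of what the source reports. "The series", "measured", "known", "first", "only" and "open" are said of these compounds alone.

Going by the values given here, compound 2 `O[C@@H]1[C@@H](OCc2ccccc2)[C@H](OCc2ccccc2)[C@@H](COCc2ccccc2)O[C@H]1CC1CCCCC1` gives 4100 nM in a functional assay on HL-60 cells (Homo sapiens) for antiproliferative activity, read by MTT assay (on this read-out lower numbers stand for stronger inhibition and higher numbers for weaker inhibition), and stands lowest of the two numbers so far. Compound 1 `O[C@@H]1[C@@H](OCc2ccccc2)[C@H](OCc2ccccc2)[C@@H](COCc2ccccc2)O[C@@H]1CC1CCCCC1` gives 17200 nM in this assay; the step of a 4.2-fold lower number from compound 1 to compound 2 (0.62 log units; beyond the scatter) rests only on (the fact that compounds 1 and 2 differ only in the configuration as drawn). Compound 3 `CC(=O)O[C@@H]1[C@@H](OCc2ccccc2)[C@H](OCc2ccccc2)[C@@H](COCc2ccccc2)O[C@H]1Cc1ccccc1`, which carries a benzyl group and an acetate in place of the hydroxy group, is reported as "not active" (no number reported) in this assay, without a number. Compound 4 `O[C@@H]1[C@@H](OCc2ccccc2)[C@H](OCc2ccccc2)[C@@H](COCc2ccccc2)O[C@H]1c1ccccc1` differs from compound 2 by phenyl in place of cyclohexylmethyl on a saturated ring carbon. Among the compounds with values here, no measured step touches this kind of change, so nothing here fixes its size or direction; the outcome for compound 3 is the only hint that an aromatic group at this ring carbon may weaken activity. Compound 4 is therefore expected to give about 8000 nM, within 2500 nM to 25000 nM, meaning an estimated step of a 2.0-fold higher number from compound 2 to compound 4 (0.29 log units; within the scatter).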

Compound 4, half-maximal inhibitory concentration: 26300 nM
Compound 4: the middle estimate sits 3.3-fold (0.52 log units) below what was measured; measured number outside the range, above it.
By their numbers in this assay, from the lowest: compound 2; then compounds 1 and 4 (each within the scatter of the next).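

Swapping the group itself at this saturated ring carbon, next to the ring oxygen, has a measurable effect in this assay: a 6.4-fold higher number from compound 2 to compound 4 (0.81 log units; beyond the scatter). Phenyl therefore retains a reported number but gives weaker inhibition than cyclohexylmethyl here, which the change in configuration alone could not show. Nothing available explains this step. Phenyl differs from cyclohexylmethyl both in having an aromatic ring and in its attachment, and the compounds shown do not separate these two changes. As far as these compounds go, how a directly attached cyclohexyl or an amine at this carbon would behave remains open.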